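Replacing a trifluoromethylphenyl with a difluorophenyl on the core

The compounds below may be only part of what the source reports. "The series", "measured", "known", "first", "only" and "open" are said of these compounds alone.

Compound 3 `O=C(O)Cc1sc(C(c2ccccc2)c2ccccc2)nc1-c1ccc(C(F)(F)F)cc1` gives 1100 nM in an in vitro assay on HEK385-7 cells for displacement of a labelled ligand from prostaglandin D2 receptor 2 (Homo sapiens) (a higher number here means a weaker inhibitor, a lower number a stronger inhibitor), the highest number of the three measured compounds. Compound 1 `N#Cc1cc(-c2nc(C(c3ccc(F)cc3)c3ccc(F)cc3)sc2CC(=O)O)ccc1F` gives 57 nM in this assay, and compound 2 `O=C(O)Cc1sc(C(c2ccc(F)cc2)c2ccc(F)cc2)nc1-c1ccnc(F)c1` gives 0.48 nM; both of those numbers lie well beneath that of compound 3.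

Compound 4 `O=C(O)Cc1sc(C(c2ccccc2)c2ccccc2)nc1-c1ccc(F)c(F)c1` has not been measured. It differs from compound 3 in one place: 3,4-difluorophenyl in place of 4-(trifluoromethyl)phenyl on an aromatic carbon. Among the measured compounds shown here, the aromatic ring at this position is the same one that is exchanged in the only measured step, a 120-fold lower number from compound 1 to compound 2 (2.07 log units; beyond the scatter), which shows that the identity of the group on this carbon can move the number a great deal. That step, however, introduces a pyridine, while the present change keeps a carbon-only ring and alters only its fluorine-bearing pattern, so it gives no direct guide to the direction. Compound 1 and compound 3 both carry fluorinated phenyl rings here, but they also differ in the diphenylmethyl portion, so their two values can be compared only as they stand.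

On this basis the step is expected to be modest and downward, a 3.7-fold lower number from compound 3 to compound 4 (0.56 log units; beyond the scatter), and compound 4 is estimated to give 300 nM in this assay, within the range 60 nM to 1500 nM.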

Compound 4, half-maximal inhibitory concentration: 4.1 nM
The estimate for compound 4 lay 73-fold (1.86 log units) above the measured number; measured number outside the range, below it.
By their numbers in this assay, from the lowest: compound 2; then compound 4; then compound 1; then compound 3.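

In this assay, exchanging 4-(trifluoromethyl)phenyl for 3,4-difluorophenyl on this aromatic carbon gives a 270-fold lower number from compound 3 to compound 4 (2.43 log units; beyond the scatter), so a large step at this position does not depend on bringing in a ring nitrogen. The earlier step, a 120-fold lower number from compound 1 to compound 2 (2.07 log units; beyond the scatter), did introduce a pyridine, whereas here a six-membered aromatic ring of carbon only replaces another such ring, both with no hydrogen-bond donors or acceptors and no net charge, and the substituents on the ring are what differ. Nothing available here accounts for the size of this step.

The compounds shown leave open whether the step comes from removing the trifluoromethyl group or from adding the fluorines, and a plain phenyl ring or a phenyl ring with a single fluorine or chlorine at this carbon would be needed to separate the two. Among the compounds shown here, they also leave open whether the 3,4-difluorophenyl group, or the 2-fluoropyridin-4-yl group of compound 2, behaves in the same way when the other portion of the molecule is changed, since no measured pair tests either group on both diphenylmethyl portions.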